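Cyanophenyl in place of chlorophenyl on the amide nitrogen

The source may report more compounds than this note shows. Statements on the series, on what has been measured and on what is new or still open speak of the compounds shown alone.

compound 1, `COc1cc2nc(SCC(=O)Nc3ccc(C(F)(F)F)cc3)nc(Nc3c(C)cc(/C=C/C#N)cc3C)c2cc1OC`: > 211000 nM
compound 2, `COc1cc2nc([S+]([O-])CC(=O)Nc3cccc(Cl)c3)nc(Nc3c(Cl)cc(/C=C/C#N)cc3Cl)c2cc1OC`: 68900 nM

Of the compounds shown here, two have been tested in an ADME assay on MT4 cells (Homo sapiens) for cytotoxicity, read by MTT assay, with a stated time of 5 days; on this read-out higher numbers stand for lower toxicity in this test and lower numbers for higher toxicity in this test. For compound 1 the value > 211000 nM is a limit of the assay and not a number. Compound 2 gives 68900 nM. Compound 2 therefore stands alone as the only number shown; the other value is a limit (the limit of > 211000 nM in this assay, at which 1 of the 2 values shown sits). Compound 3, `COc1cc2nc([S+]([O-])CC(=O)Nc3ccc(C#N)cc3)nc(Nc3c(Cl)cc(/C=C/C#N)cc3Cl)c2cc1OC`, has not yet been measured. It differs from compound 2 in one place: 4-cyanophenyl in place of 3-chlorophenyl on an amide-type nitrogen. Within the data shown here, no pair of measured compounds differs in a single place, so no measured step exists to compare with. For this change the expectation in this assay is a step no larger than the usual scatter, leaning, if anything, towards a higher number. The expected value for compound 3 is 85000 nM, with a range from 30000 nM to 200000 nM. This means an expected step of a 1.2-fold higher number from compound 2 to compound 3 (0.09 log units; within the scatter).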

Compound 3, half-maximal cytotoxic concentration: >= 188000 nM
Compound 3: no number, only a limit (the forecaster's own chance of this, stated with the estimate: 30%); middle value at least 2.2-fold (0.34 log units) away from the limit.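

In this assay, among these compounds, 4-cyanophenyl in place of 3-chlorophenyl on the amide-type nitrogen gives an at least 2.7-fold higher number from compound 2 to compound 3 (0.43 log units; beyond the scatter), the first step that can be read at this position, and it shows that the group on this nitrogen can move the read-out by more than the usual scatter. The value of compound 3 is a limit of the assay and not a number: the limit of >= 188000 nM in this assay, at which 1 of the 3 values shown sits. From the compounds shown here alone, the step therefore gives only a lower bound on the size of the change, and its true size remains unknown.

This single step swaps the chlorine for a nitrile and also changes the name's ring number from 3 to 4, so the compounds shown cannot separate those two changes. Going by these compounds, how an amine or a carboxylic acid in place of the nitrile on this phenyl ring would read in this assay also remains open.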